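The compounds below may be only part of what the source reports. "The series", "measured", "known", "first", "only" and "open" are said of these compounds alone.

Compound 1 `COc1cc(/C=C/C(=O)c2cccc(NC(=O)c3cccs3)c2)ccc1O` carries a thiophen-2-yl group on a carbonyl carbon next to an amide-type nitrogen. In a functional assay on HUVEC cells (Homo sapiens) for inhibition, tested at 10 ug/mL (on this read-out lower numbers stand for a weaker effect and higher numbers for a stronger effect at the one concentration tested), compound 1 gives 90%, the higher of the two numbers at hand. Compound 2 `COc1cc(/C=C/C(=O)c2cccc(NC(=O)c3ccc(Cl)cc3)c2)ccc1O` gives 66% in this assay; swapping thiophen-2-yl for 4-chlorophenyl on that carbonyl carbon brought a number 24 percentage points lower from compound 1 to compound 2 (beyond the scatter), a modest loss. Compound 3 `COc1cc(/C=C/C(=O)c2cccc(NC(=O)c3ccccc3)c2)ccc1O` is not yet measured. It differs from compound 1 in this way: phenyl in place of thiophen-2-yl on a carbonyl carbon. Within the data shown here, the single measured step that bears on it is the one to compound 2, which also replaces thiophen-2-yl with a six-membered ring of carbon only on the same carbonyl carbon. A drop is therefore expected, probably no larger than the one seen with the chlorinated ring, a number 16 percentage points lower from compound 1 to compound 3 (beyond the scatter). Compound 3 is estimated at 74%, within a range from 58% to 88%.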

Compound 3, a percentage reported as inhibition, at one concentration (the size of the read-out at that concentration, not a potency): 69%
Beside the measured number, compound 3's estimate is 5 percentage points above it; the range from low to high includes it.
By their numbers in this assay, from the lowest: compounds 2 and 3 (each within the scatter of the next); then compound 1.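

In this assay the step of a number 21 percentage points lower from compound 1 to compound 3 (beyond the scatter) shows that a plain phenyl ring on this carbonyl carbon also falls short of thiophen-2-yl, so the earlier loss did not depend on the chloro group. The step of a number 3 percentage points higher from compound 2 to compound 3 (within the scatter) agrees: with or without chloro, the six-membered ring of carbon only reads the same within the scatter, and among these three compounds the difference lies in replacing thiophen-2-yl. Nothing at hand explains why thiophen-2-yl stands higher here.

Thiophen-2-yl differs from phenyl in both ring size and its sulfur atom, so these compounds cannot separate the two; furan-2-yl, with oxygen in place of sulfur, would help to tell them apart. On these data alone, how a non-aromatic group such as cyclopentyl or a short alkyl chain would fare on this carbonyl carbon also remains open.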